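Adding a Methyl to the Amine of a Pyrrolyl Sulfone

A few compounds are considered here, and "the series" means these few. Any claim that something is new, unique, unknown or untested is made for them only; others in the source may bear on it.

Compound 1 `CNCC1CCCc2cc(S(=O)(=O)c3ccccc3)ccc21` and compound 2 `CN(C)CC1CCCc2cc(S(=O)(=O)c3ccccc3)ccc21` share a core and differ at only one point: methyl in place of hydrogen on an amine nitrogen. In an assay on isolated protein for displacement of a labelled ligand from 5-hydroxytryptamine receptor 6 (Homo sapiens) (a lower number here means a stronger inhibitor, a higher number a weaker inhibitor), compound 1 gives 0.316 nM, and compound 2 gives 0.0631 nM. That single change produced a 5.0-fold lower number from compound 1 to compound 2 (0.70 log units; beyond the scatter), so the methyl on the amine nitrogen went together with a stronger inhibitor.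

Compound 3 `NC[C@@H]1CCCc2cc(S(=O)(=O)c3cc[nH]c3)ccc21` carries a different core, with a pyrrole in place of the benzene on the sulfone; how the two cores differ is not broken down here. In this assay compound 3 gives 0.316 nM, which stands level with compound 1 at the digits given, and both sit well above compound 2.

Compound 4 `CNC[C@@H]1CCCc2cc(S(=O)(=O)c3cc[nH]c3)ccc21` has not yet been measured. It is built from compound 3 by the following change: methyl in place of hydrogen on an amine nitrogen. Going by the values given here, this is the same kind of change as the one from compound 1 to compound 2, but not the same: there the amine nitrogen had two saturated chain carbons as its other neighbours, here it has one. Because the earlier step read a 5.0-fold lower number from compound 1 to compound 2 (0.70 log units; beyond the scatter), a step in the same direction is expected here, tempered by the different surroundings of the nitrogen and by the changed core, so the expected step is a 3.2-fold lower number from compound 3 to compound 4 (0.50 log units; beyond the scatter). For compound 4 the expected value in this assay is therefore 0.1 nM, most likely between 0.03 nM and 0.4 nM.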

Compound 4, inhibition constant: 0.159 nM
The estimate for compound 4 lay 1.6-fold (0.20 log units) below the measured number; the range from low to high includes it.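

In this assay the methyl in place of hydrogen on an amine nitrogen reads a 2.0-fold lower number from compound 3 to compound 4 (0.30 log units; within the scatter) and so, on the core of compound 3, this step alone cannot be told apart from the ordinary spread of repeat measurements. Set side by side, the steps on the two cores cannot be told apart either: the same change on two cores in this assay, a 5.0-fold lower number (0.70 log units; beyond the scatter) from compound 1 to compound 2 and a 2.0-fold lower number (0.30 log units; within the scatter) from compound 3 to compound 4, 2.5-fold (0.40 log units) apart, within the scatter of two such steps. Going by these compounds alone, this fits the idea that the change carries over from one core to the other, but it does not prove it, since only the step on the core of compound 1 stands clear of the scatter, and two pairs are a slim basis for any rule, especially as the amine nitrogen has different neighbours in the two pairs, with two saturated chain carbons in one and a single one in the other.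

The compounds shown leave open whether an ethyl group or a longer chain on the amine nitrogen would follow the same course as methyl on either core. They also leave open how a second methyl on the nitrogen of compound 4 would read, which would give the pyrrole-bearing core a direct counterpart to compound 2.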